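Swapping Bromo for Acetoxy on a Fused Ring Core

The source may hold more compounds than are shown below. What is called first, only, known or untested is meant among the compounds shown, and "the series" means these compounds.

Compound 1, `Cc1cccn2cc(-c3ccc(NC(=O)Nc4cc(C(C)(C)C)on4)cc3)nc12`, gives 248 nM.
Compound 2, `CC(C)(C)c1cc(NC(=O)Nc2ccc(-c3cn4ccc(Br)cc4n3)cc2)no1`, gives 9.59 nM.

For the measured compounds named here, in a functional assay on MV4-11 cells (Homo sapiens) for cytotoxicity, read by MTT assay, with a stated time of 72 h (a higher number here means a weaker inhibitor, a lower number a stronger inhibitor), compound 2 holds the lowest of the two numbers measured so far, and the only neighbour, compound 1, sits higher by a margin well beyond the usual scatter. Compound 3, `CC(=O)Oc1ccn2cc(-c3ccc(NC(=O)Nc4cc(C(C)(C)C)on4)cc3)nc2c1`, follows from compound 2 by a single change: acetoxy in place of bromo on an aromatic carbon. Going by the values given here, no step between two measured compounds covers such an exchange, so the measured pair gives no direct guide to its size or direction. The expected step of a 4.2-fold higher number from compound 2 to compound 3 (0.62 log units; beyond the scatter) is therefore taken as a moderate move toward a weaker inhibitor, with real uncertainty on both sides. On that basis compound 3 is estimated at 40 nM in this assay, within a range from 8 nM to 200 nM.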

Compound 3, half-maximal inhibitory concentration: 29.4 nM
For compound 3 the middle estimate is 1.4-fold (0.13 log units) above the measured one; low and high end bracket the measured number.
By their numbers in this assay, from the lowest: compound 2; then compound 3; then compound 1.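

In this assay the position opposite the ring nitrogen takes more than a single bromine: the four heavy atoms of acetoxy, with its two hydrogen-bond acceptors, give a 3.1-fold higher number from compound 2 to compound 3 (0.49 log units; beyond the scatter) and so only a modest loss. The step lies beyond the usual scatter, so bromo remains the better of these two groups here, yet compound 3 still reads 29.4 nM and the position clearly does not demand bromo. No separate measurement bears on this result, so the size and direction of the step remain unexplained.

On these data alone, what stays open is whether the outcome depends on the whole acetoxy group or only on the oxygen joined to the ring, which a hydroxy or methoxy group at this same position would help to separate. This single pair also cannot show whether the same exchange would give a similar step on a different core.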